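Swapping the acetyl end for a bulkier ester

The compounds below may be only part of what the source reports. "The series", "measured", "known", "first", "only" and "open" are said of these compounds alone.

In a functional assay on K562 cells (Homo sapiens) for antiproliferative activity (a higher number here means a weaker inhibitor of growth, a lower number a stronger inhibitor of growth), compound 1 `COCCCCCCCCCCC/C=C1\CC(CO)(COC(=O)C(C)(C)C)OC1=O` gives 0.516 ug/mL, compound 2 `CC(C)(C)C(=O)OCC1(CO)C/C(=C\CCCCCCCCCCCCCCC=O)C(=O)O1` gives 5.11 ug/mL and compound 3 `CC(=O)OCCCCCCCCCCCCCCC/C=C1\CC(CO)(COC(=O)C(C)(C)C)OC1=O` gives 0.959 ug/mL. Compound 3 thus sits with compound 1 and apart from compound 2: the series shows a 1.9-fold higher number from compound 1 to compound 3 (0.27 log units; within the scatter), against a 5.3-fold lower number from compound 2 to compound 3 (0.73 log units; beyond the scatter). Compound 4 `CC(C)(C)C(=O)OCCCCCCCCCCCCCCC/C=C1\CC(CO)(COC(=O)C(C)(C)C)OC1=O` carries tert-butyl in place of methyl on a carbonyl carbon, so acetoxy becomes ((tert-butyl)carbonyl)oxy. Within the data shown here, no measured step makes this exact change. The closest evidence is the pair of steps into compound 3, and only the formyl compound stands apart, as a 9.9-fold higher number from compound 1 to compound 2 (1.00 log units; beyond the scatter) shows. Compound 4 keeps the ester type of compound 3, so no step beyond the scatter is expected in this assay. The expected step is a 1.1-fold lower number from compound 3 to compound 4 (0.03 log units; within the scatter). For compound 4 the estimate is 0.9 ug/mL, with an expected range of 0.35 ug/mL to 2.4 ug/mL.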

Compound 4, concentration for 50% growth inhibition: 0.352 ug/mL
For compound 4 the middle estimate is 2.6-fold (0.41 log units) above the measured one; the measured number falls inside the stated range.
By their numbers in this assay, from the lowest: compounds 4, 1 and 3 (each within the scatter of the next, the first and the last beyond it); then compound 2.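

In this assay, the ester on this chain still has room to move the number: tert-butyl in place of methyl on a carbonyl carbon gives a 2.7-fold lower number from compound 3 to compound 4 (0.44 log units; beyond the scatter) and so lies beyond the scatter. The ((tert-butyl)carbonyl)oxy compound matches the methoxy compound, with a 1.5-fold lower number from compound 1 to compound 4 (0.17 log units; within the scatter) within the scatter, while a 15-fold lower number from compound 2 to compound 4 (1.16 log units; beyond the scatter) sets it well apart from the formyl compound. Nothing available accounts for the step from acetoxy to ((tert-butyl)carbonyl)oxy.

Open, as far as these compounds go, is whether a free hydroxyl, a carboxylic acid or an amine in place of the ester would hold this level. From the compounds shown here alone, a longer chain also remains untested in these compounds.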